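Brine shrimp cytotoxicity notes on chalcone sulfonylureas

The compounds below may be only part of what the source reports. "The series", "measured", "known", "first", "only" and "open" are said of these compounds alone.

Compound 2, `Cc1ccc(S(=O)(=O)NC(=O)Nc2ccccc2C(=O)/C=C/c2ccc(O)cc2)cc1`, gives 24.3 ug/mL in an ADME assay on the whole organism for cytotoxicity, with Artemia salina as the target, with a stated time of 24 h; a higher number here means that more compound is needed for the effect, a lower number that less compound is needed. Among the compounds with values here, of the two numbers recorded it stands at one end, but its only neighbour, compound 1, `Cc1ccc(/C=C/C(=O)c2ccccc2NC(=O)NS(=O)(=O)c2ccc(C)cc2)cc1`, gives 15.3 ug/mL, and the single measured step, a 1.6-fold higher number from compound 1 to compound 2 (0.20 log units; within the scatter), stays within the scatter.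

Compound 3, `Cc1ccc(S(=O)(=O)NC(=O)Nc2ccccc2C(=O)/C=C/c2ccccc2[N+](=O)[O-])cc1`, has not yet been measured in this assay. It differs from compound 2 by 2-nitrophenyl in place of 4-hydroxyphenyl on a double-bonded chain carbon bound to a double-bonded chain carbon. Within the data shown here, no measured step touches either of these groups: the one step recorded exchanged a hydroxy for a methyl on an aromatic carbon and, as stated, fell within the scatter, so it bears only loosely on this larger exchange. Nothing in the two measured compounds points to a step in this assay beyond the scatter in either direction, and the expected step of a 1.2-fold lower number from compound 2 to compound 3 (0.08 log units; within the scatter) is therefore taken as small, with the range widened for the uncertainty. Compound 3 is expected to give 20 ug/mL in this assay, with a range from 7 ug/mL to 55 ug/mL.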

Compound 3, concentration for half-maximal effect: 40.1 ug/mL
Beside the measured number, compound 3's estimate is 2.0-fold (0.30 log units) below it; the range from low to high includes it.
By their numbers in this assay, from the lowest: compounds 1, 2 and 3 (each within the scatter of the next, the first and the last beyond it).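

In this assay, within the data shown here, the exchange on a double-bonded chain carbon bound to a double-bonded chain carbon gives the first step that lies beyond the scatter: with 2-nitrophenyl in place of 4-methylphenyl, the result is a 2.6-fold higher number from compound 1 to compound 3 (0.42 log units; beyond the scatter), a modest step showing that this position can carry a readable difference in the amount of compound needed. Against 4-hydroxyphenyl at the same place, the exchange to 2-nitrophenyl gives a 1.7-fold higher number from compound 2 to compound 3 (0.22 log units; within the scatter), so the separation is seen against only one of the two earlier groups, and compound 2 cannot be told apart from either compound 1 or compound 3. No measured information on the properties of these groups bears on this result, so the step stays a bare observation.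

As far as these compounds go, it remains open whether the step belongs to the nitro group as such, a question that an amine or a nitrile on the phenyl ring at this place would address. From the compounds shown here alone, it also remains open whether the step carries over when the shared core changes elsewhere, for instance with a carboxylic acid in place of the methyl group that compound 1 and compound 3 share in the core.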